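A few compounds are considered here, and "the series" means these few. Any claim that something is new, unique, unknown or untested is made for them only; others in the source may bear on it.

Of the compounds shown here, three built on one shared core have been measured in a physicochemical assay for lipophilicity, at pH 7.4; a lower number here means a more polar compound, a higher number a more lipophilic compound. Compound 1 `CCc1nc2nc(C)cc(Nc3ccc(C(F)(F)F)cc3)n2n1` gives 3, compound 2 `Cc1cc(Nc2ccc(C(F)(F)F)cc2)n2nc(CCO)nc2n1` gives 2.2, and compound 3 `Cc1cc(Nc2ccc(Cl)cc2)n2nc(C(C)C)nc2n1` gives 3.2. Compound 2 stands lowest of the three; compound 1 is nearest to it and compound 3 furthest, and both gaps lie beyond the scatter. Going by the values given here, the one step between compounds that differ in a single place is a number 0.80 log units lower from compound 1 to compound 2 (beyond the scatter), which came with a hydroxy in place of hydrogen on a saturated chain carbon, two bonds along the chain from an aromatic carbon.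

Compound 4 `COCCc1nc2nc(C)cc(Nc3ccc(C(F)(F)F)cc3)n2n1` has not yet been measured. It differs from compound 2 by methyl in place of hydrogen on an oxygen on a saturated carbon, so that hydroxy becomes methoxy and 2-hydroxyethyl becomes 2-methoxyethyl. Among the compounds with values here, no measured pair here shows a methyl put onto an oxygen, so the size of this change cannot be read off directly. The step that bears on it is a number 0.80 log units lower from compound 1 to compound 2 (beyond the scatter), which shows what the entering hydroxy did; turning that hydroxy into a methoxy is expected to recover part of that shift rather than all of it. The step expected is a number 0.50 log units higher from compound 2 to compound 4 (beyond the scatter). The value expected for compound 4 in this assay is 2.7, within a range from 2.3 to 3.1.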

Compound 4, distribution coefficient: 2.7
The estimate for compound 4 equals the measured number at the digits printed, and the stated range covers the measured number.
By their numbers in this assay, from the lowest: compound 2; then compounds 4, 1 and 3 (each within the scatter of the next, the first and the last beyond it).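

In this assay the step of a number 0.50 log units higher from compound 2 to compound 4 (beyond the scatter) shows that adding a single methyl to the oxygen at the end of this chain is enough to produce a change beyond the scatter, so the end of the 2-hydroxyethyl chain is sensitive to whether that oxygen carries a hydrogen. With a number 0.80 log units lower from compound 1 to compound 2 (beyond the scatter) for the hydroxy and a number 0.30 log units lower from compound 1 to compound 4 (within the scatter) for the methoxy, each in place of hydrogen on the same chain carbon, the free hydroxy gives a clear difference from the ethyl chain of compound 1, while compound 4 cannot be told apart from compound 1 even though its chain also contains an oxygen. The data offer no explanation of why these two oxygen-bearing groups differ in this way.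

An amine or a carboxylic acid at the end of the chain, or a longer chain ending in methoxy, could each give a different result at this position. Going by these compounds, it also remains open whether hydroxy to methoxy would give a step of similar size on the core of compound 3, which carries a chloro group where compounds 1, 2 and 4 carry trifluoromethyl.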